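Swapping Phenoxy for Dimethylamino in a Melanoma Cell Assay

The compounds below may be only part of what the source reports. "The series", "measured", "known", "first", "only" and "open" are said of these compounds alone.

Compound 3 `Cc1cc(O)cc(-c2nn(CC#N)cc2-c2ccnc(-c3ccc(Oc4ccccc4)cc3)c2)c1` was tested in a functional assay on SK-MEL-28 cells (Homo sapiens) for cytotoxicity, read by sulforhodamine B assay, with a stated time of 48 h, tested at 100 nM (on this read-out lower numbers stand for a stronger effect and higher numbers for a weaker effect at the one concentration tested), where compound 3 gives 95%. This places compound 3 level with compound 1 `COc1cc(C)cc(-c2c(-c3ccnc(-c4ccc(C(C)=O)cc4)c3)cnn2CC#N)c1`, which gives 95%; together these two are the highest of the three numbers, meaning the weakest effect. Compound 2 `COc1cc(C)cc(-c2nn(CC#N)cc2-c2ccc(-c3cccc(C(C)=O)c3)nc2)c1` gives 74%, a number lower than that of compound 3 by an amount beyond the scatter, and so a stronger effect. Compound 4 `Cc1cc(O)cc(-c2nn(CC#N)cc2-c2ccnc(-c3ccc(N(C)C)cc3)c2)c1` is not yet measured. It differs from compound 3 in one place: dimethylamino in place of phenoxy on an aromatic carbon. Among the measured compounds shown here, no measured pair shows this exact change, so the size of the step is open. The expected step is a number 5 percentage points lower from compound 3 to compound 4 (within the scatter), that is, none beyond the scatter. Compound 4 is estimated at 90%, within a range from 70% to 105%.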

Compound 4, a percentage reported as activity, at one concentration (the size of the read-out at that concentration, not a potency): 96%
Estimate against measurement, compound 4: 6 percentage points below; measured number inside the range.
By their numbers in this assay, from the lowest: compound 2; then compounds 1, 3 and 4 (each within the scatter of the next).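

Among the compounds shown here, putting dimethylamino in place of phenoxy gives a number 1 percentage points higher from compound 3 to compound 4 (within the scatter) in this assay, the first step here that isolates a change at this position, on an aromatic carbon para to a large group. The ring-free group of 3 heavy atoms and the ring-bearing group of 7 therefore cannot be told apart in this read-out, and both compounds show only a weak effect at the one concentration tested. Nothing available here explains this result. From the compounds shown here alone, whether a carboxylic acid or a morpholine ring at this position would give a clearly lower number, and so a stronger effect, remains open.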